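Removing the hydroxy group from compound 1

The source may hold more compounds than are shown below. What is called first, only, known or untested is meant among the compounds shown, and "the series" means these compounds.

Measured so far in a functional assay on HeLa cells (Homo sapiens) for inhibition, read by CCK-8 assay, with a stated time of 48 h (on this read-out lower numbers stand for stronger inhibition and higher numbers for weaker inhibition), are three compounds:
- compound 1 `O=C(NCCNS(=O)(=O)c1ccc(-c2ccccc2OCc2cccc(O)c2)s1)Nc1cc(C(F)(F)F)cc(C(F)(F)F)c1` gives 17300 nM
- compound 2 `COc1ccc(Oc2ccccc2-c2ccsc2S(=O)(=O)N2CCN(C(=O)Nc3cccc([N+](=O)[O-])c3)CC2)cc1OC` gives > 50000 nM
- compound 3 `O=S(=O)(NCCNC(=S)Nc1ccc(Cl)cc1)c1ccc(-c2ccccc2OCc2ccccc2)s1` gives 7000 nM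

Compound 1 holds the higher of the two true numbers, and compound 3 at 7000 nM lies lower by more than the usual scatter. Compound 2 at > 50000 nM is a limit of the assay and not a number.

Compound 4 `O=C(NCCNS(=O)(=O)c1ccc(-c2ccccc2OCc2ccccc2)s1)Nc1cc(C(F)(F)F)cc(C(F)(F)F)c1` has yet to be measured. It departs from compound 1 by a single change, (hydrogen in place of hydroxy on an aromatic carbon), with hydrogen in place of hydroxy on an aromatic carbon, so that 3-hydroxybenzyl becomes benzyl.

Among the compounds with values here, no measured pair in this assay isolates this change. Within the data shown here, a modest move towards a lower number is expected, perhaps no larger than the scatter, and compound 3 at 7000 nM is the only reading that guides this direction. The estimated step is a 1.6-fold lower number from compound 1 to compound 4 (0.20 log units; within the scatter) in this expectation. Compound 4 is expected at 11000 nM with an estimated range from 4500 nM to 27000 nM in the coming measurement.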

Compound 4, half-maximal inhibitory concentration: 13500 nM
Compound 4: the middle estimate sits 1.2-fold (0.09 log units) below what was measured; measured number inside the range.
By their numbers in this assay, from the lowest: compounds 3, 4 and 1 (each within the scatter of the next, the first and the last beyond it). At a limit, above all of these: compound 2.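

Replacing 3-hydroxybenzyl with benzyl, hydrogen in place of hydroxy on an aromatic carbon, gives in this assay a 1.3-fold lower number from compound 1 to compound 4 (0.11 log units; within the scatter). Within the data shown here, this is the first comparison that isolates a single change, and it shows that the hydroxy group can leave this position with no difference that can be told from the usual scatter, so inhibition of HeLa cells stays at the same level without it. Both values are true numbers, so the step can be read, and neither compound stands at the limit seen in this series: the limit of > 50000 nM in this assay, at which 1 of the 4 values shown sits.

The compounds shown leave open how an amine, a methoxy group or a carboxylic acid would read at the same place on the ring. They also leave open whether the hydroxy group would count for as little with the other end of compound 3.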